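Chlorophenyl Placement in a Hydrazone Series Binding Receptor 1

A few compounds are considered here, and "the series" means these few. Any claim that something is new, unique, unknown or untested is made for them only; others in the source may bear on it.

The measured compounds, with their results in an assay on isolated protein for binding affinity to corticotropin-releasing factor receptor 1 (Homo sapiens); on this read-out lower numbers stand for stronger inhibition and higher numbers for weaker inhibition:

Compound 1 `CC(=O)/C(=N\c1ccccc1Cl)NNc1ccccc1Cl`: the result is only a limit of the assay, > 10000 nM.
Compound 2 `CC(=O)/C(=N\c1ccc(Cl)cc1)NNc1ccccc1Cl`: this assay gives 3870 nM.
Compound 3 `CC(=O)/C(=N\c1ccccc1Cl)NNc1ccccc1C(F)(F)F`: the result is only a limit of the assay, > 10000 nM.

Compound 2 differs from compound 1 by one change, (4-chlorophenyl in place of 2-chlorophenyl on a double-bonded nitrogen). In this assay that change gave an at least 2.5-fold lower number from compound 1 to compound 2 (0.41 log units; beyond the scatter). The step can only be read as a minimum, because of the limit of > 10000 nM in this assay, at which 2 of the 3 values shown sit.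

Compound 3 differs from compound 1 on the other ring, (trifluoromethyl in place of chloro on an aromatic carbon). In this assay that gave a step that the two limits leave unreadable from compound 1 to compound 3, so whether this change helps or hurts cannot be told from these two compounds.

Compound 4 `CC(=O)/C(=N\c1ccc(Cl)cc1)NNc1ccccc1C(F)(F)F` has not been measured. It differs from compound 3 by 4-chlorophenyl in place of 2-chlorophenyl on a double-bonded nitrogen, the same kind of change as from compound 1 to compound 2, and the place is the same in both. Compound 4 is therefore expected to show an at least 1.4-fold lower number from compound 3 to compound 4 (0.15 log units; that floor lies within the scatter), a step of roughly the size seen in an at least 2.5-fold lower number from compound 1 to compound 2 (0.41 log units; beyond the scatter), though the starting point is itself only a limit and the result could still fall outside the measurable range. With that, compound 4 is estimated at 7000 nM in this assay, with a likely range from 2000 nM to 30000 nM.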

Compound 4, inhibition constant: > 10000 nM
Compound 4 was reported as a limit; the forecaster's own chance of this, stated with the estimate: 45%; middle value at least 1.4-fold (0.15 log units) from the limit.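

In this assay compound 4 gives > 10000 nM, which is only a limit of the assay. Among these compounds, the one new step that can be read concerns a different change, trifluoromethyl in place of chloro on an aromatic carbon, and it gives an at least 2.5-fold higher number from compound 2 to compound 4 (0.41 log units; beyond the scatter), so with the 4-chlorophenyl group in place, this swap weakens the result. The gain seen on the core of compound 1 from 4-chlorophenyl in place of 2-chlorophenyl is neither confirmed nor ruled out on the core of compound 3, and the new step between those two cores' limits cannot be read, because both compounds in that pair sit at the same ceiling: the limit of > 10000 nM in this assay, at which 3 of the 4 values shown sit.

Among the compounds shown here, compound 2 remains the only compound here with a measured number, so the size of any gain from this change on the trifluoromethyl core stays unknown, and a more strongly binding starting compound would be needed to read it. The compounds shown also leave open how a methoxy group, an amine or a carboxylic acid in place of the chloro of compound 2 would fare on this read-out.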